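Swapping an aryl for a decyl chain on the triazole

This account rests on a few compounds, and the source may have more. Where it says the series, first, only, none or still open, it means among the compounds named here.

Among the compounds with values here, compound 1 `O=C1O[C@H]([C@@H](O)Cn2cc(-c3ccc(Br)cc3)nn2)C(OCc2ccccc2)=C1OCc1ccccc1` is the only member of this small set with a definite number in a functional assay on CFPAC-1 cells (Homo sapiens) for antiproliferative activity, read by MTT assay, with a stated time of 72 h (on this read-out lower numbers stand for stronger inhibition and higher numbers for weaker inhibition), where compound 1 gives 5830 nM. Compound 2 `O=C1O/C(=C\Cn2cc(-c3cc(F)cc(F)c3)nn2)C(OCc2ccccc2)=C1OCc1ccccc1` is recorded in this assay as "not active" (no number reported), with no number attached. Compound 3 `CC(C)(C)OC(=O)N1CCN(C(=S)SCc2cn(C[C@H](O)[C@H]3OC(=O)C(OCc4ccccc4)=C3OCc3ccccc3)nn2)CC1` reaches only a limit of this assay, > 100000 nM, which is the limit of > 100000 nM in this assay, at which 1 of the 3 values shown sits, and not a measured number. Within the data shown here, no step between two measured compounds can therefore be described here; only what each value shows.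

Compound 4 `CCCCCCCCCCc1cn(C[C@H](O)[C@H]2OC(=O)C(OCc3ccccc3)=C2OCc2ccccc2)nn1` carries the same shared core as compound 1 and differs from it in one place: decyl in place of 4-bromophenyl on an aromatic carbon. Among the measured compounds shown here, with no measured step of this kind to lean on, the size of the change from compound 1 to compound 4 is expected to stay within the usual scatter, with at most a slight lean toward stronger inhibition, as a 1.5-fold lower number from compound 1 to compound 4 (0.16 log units; within the scatter). Compound 4 is thus estimated at 4000 nM in this assay, within a range from 800 nM to 25000 nM.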

Compound 4, half-maximal inhibitory concentration: 40300 nM
For compound 4 the middle estimate is 10-fold (1.00 log units) below the measured one; the measured number lies above the stated range.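

Within the data shown here, this is the first measured step at this position, and it shows that the position is not indifferent to what it carries: in this assay, decyl in place of 4-bromophenyl on an aromatic carbon of the five-membered ring gives a 6.9-fold higher number from compound 1 to compound 4 (0.84 log units; beyond the scatter), so inhibition is weaker. The change is modest, however, and compound 4 still gives a definite number, so a group with no ring at this place does not abolish the read-out. Compound 3, with a different group at this ring carbon, gives no number, only a limit: the limit of > 100000 nM in this assay, at which 1 of the 4 values shown sits.

This single step cannot separate the loss of the aromatic ring, the loss of the bromine and the length of the chain. A plain phenyl, a shorter hexyl chain or a chain ending in an amine would be needed to tell these apart, and the compounds shown include none of them.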